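Series notes: a ring change on the side-chain nitrogen

The compounds below may be only part of what the source reports. "The series", "measured", "known", "first", "only" and "open" are said of these compounds alone.

Two compounds are measured in an assay on isolated protein for inhibition of G protein-coupled receptor kinase 6 (Homo sapiens), read by scintillation counting, radiometric assay and 33P incorporation, with a stated time of 80 min, in the presence of a further agent that is not named here; a lower number here means a stronger inhibitor, a higher number a weaker inhibitor. Compound 1 `CCc1cc(Nc2nc(N[C@@H](C)c3ccc(F)cc3)nc3cccc(F)c23)n[nH]1` gives 41 nM. Compound 2 `CCc1cc(Nc2nc(NCc3ccc(Cl)cc3)nc3cccc(OC)c23)n[nH]1` gives 16 nM, the lowest of the two numbers; the nearest is compound 1, whose number is higher by a gap beyond the scatter. Compound 3 `CCc1cc(Nc2nc(N[C@@H](C)c3ccc(Cl)cn3)nc3cccc(OC)c23)n[nH]1` differs from compound 2 by a group of 9 heavy atoms (7 carbon, 1 nitrogen, 1 chlorine; one six-membered aromatic ring with 1 hetero atom) in place of a group of 8 heavy atoms (7 carbon, 1 chlorine; one six-membered aromatic ring of carbon only), on a nitrogen on an aromatic ring. Among the measured compounds shown here, no step between measured compounds isolates this change, so the expectation rests on compound 2 alone. The step of a 1.6-fold higher number from compound 2 to compound 3 (0.19 log units; within the scatter) is expected to be small, within or near the scatter, in either direction. Compound 3 is therefore estimated at 25 nM, with a range of 8 nM to 80 nM.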

Compound 3, half-maximal inhibitory concentration: 3.5 nM
Estimate against measurement, compound 3: 7.1-fold (0.85 log units) above; the measured number lies below the stated range.
By their numbers in this assay, from the lowest: compound 3; then compound 2; then compound 1.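

In this assay, among the compounds shown here, the group on a nitrogen on an aromatic ring gives the first readable step at this position: replacing 4-chlorobenzyl gives a 4.6-fold lower number from compound 2 to compound 3 (0.66 log units; beyond the scatter), so this position responds to the change. The entering group brings the ring with 1 hetero atom and the 1 defined stereocentre together, and this single step does not separate them. Nothing measured here bears on the reason for the lower number. Open, on these data alone, is whether an unbranched pyridylmethyl group would keep that number, and how an amine or a methoxy group in place of the chlorine would read.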